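Acetamide to primary amine on the shared core

This account rests on a few compounds, and the source may have more. Where it says the series, first, only, none or still open, it means among the compounds named here.

Compound 1 `COc1ncc(-c2ccc3nc(NC(C)=O)nn3c2)cc1NS(=O)(=O)c1ccc(C)cc1` gives the lowest of the two numbers in a functional assay on U-87MG ATCC cells (Homo sapiens) for antiproliferative activity, read by MTT assay, with a stated time of 48 h (a higher number here means a weaker inhibitor, a lower number a stronger inhibitor), at 1600 nM. Compound 2 `COc1ncc(-c2ccc3nc(NC(C)=O)nn3c2)cc1NS(=O)(=O)c1ccc(C2CC2)cc1` is the nearest neighbour; compound 2 gives 3730 nM, a step of a 2.3-fold higher number from compound 1 to compound 2 (0.37 log units; beyond the scatter). Compound 3 `COc1ncc(-c2ccc3nc(N)nn3c2)cc1NS(=O)(=O)c1ccc(C)cc1` differs from compound 1 by hydrogen in place of acetyl on a nitrogen on an aromatic ring. Going by the values given here, no measured step touches this part of the shared core, so the one step on record, a 2.3-fold higher number from compound 1 to compound 2 (0.37 log units; beyond the scatter), offers no direct guide, and no change beyond the scatter is assumed. For compound 3 the expected step is a 1.3-fold higher number from compound 1 to compound 3 (0.10 log units; within the scatter). Compound 3 is estimated at 2000 nM, with a range from 600 nM to 7000 nM.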

Compound 3, half-maximal inhibitory concentration: 2510 nM
The estimate for compound 3 lay 1.3-fold (0.10 log units) below the measured number, and the stated range covers the measured number.
By their numbers in this assay, from the lowest: compounds 1, 3 and 2 (each within the scatter of the next, the first and the last beyond it).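

In this assay the swap of acetamido for amino on the shared core leaves the number within the scatter (a 1.6-fold higher number from compound 1 to compound 3 (0.20 log units; within the scatter)). Going by these compounds alone, this is the first reading at this nitrogen, whereas the earlier step concerned only the aromatic carbon bearing methyl, and for this pair the acetyl is not required to keep activity at this level. No measurement bears on why the two compounds read alike.

Open, as far as these compounds go, are other groups on this nitrogen, such as a methyl, a propionyl or a longer acyl chain. Also open, from the compounds shown here alone, is whether the amino group gives the same reading with cyclopropyl in place of methyl.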